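Amide variation on a shared core in breast cancer cells

The compounds below may be only part of what the source reports. "The series", "measured", "known", "first", "only" and "open" are said of these compounds alone.

Compounds measured so far in a functional assay on MDA-MB-231 cells (Homo sapiens) for antiproliferative activity, read by CCK-8 assay, with a stated time of 72 h; on this read-out higher numbers stand for weaker inhibition and lower numbers for stronger inhibition:
Compound 1, `O=C(Nc1cccc(-c2oc3cc(-c4ccc(F)cc4)ccc3c(=O)c2O)c1)c1ccc(Cl)cc1`, gives 12800 nM.
Compound 2, `Cc1ccccc1C(=O)Nc1cccc(-c2oc3cc(-c4ccc(F)cc4)ccc3c(=O)c2O)c1`, gives 4910 nM.
Compound 3, `COc1cccc(C(=O)Nc2cccc(-c3oc4cc(-c5ccc(F)cc5)ccc4c(=O)c3O)c2)c1`, gives 9160 nM.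

Compound 3 sits second highest of the three numbers. Its nearest neighbour is compound 1, with a 1.4-fold lower number from compound 1 to compound 3 (0.15 log units; within the scatter); the furthest is compound 2, with a 1.9-fold higher number from compound 2 to compound 3 (0.27 log units; within the scatter). Neither gap separates compound 3 from the other two in this assay.

The next compound, compound 4, `COc1ccc(C(=O)Nc2cccc(-c3oc4cc(-c5ccc(F)cc5)ccc4c(=O)c3O)c2)c(F)c1`, is built by the change (2-fluoro-4-methoxyphenyl in place of 3-methoxyphenyl on a carbonyl carbon). All three measured steps concern the same place, the aryl group on the carbonyl carbon, and so bear on it. Of those, only a 2.6-fold lower number from compound 1 to compound 2 (0.42 log units; beyond the scatter) went beyond the scatter, and that step was modest; the other two, a 1.4-fold lower number from compound 1 to compound 3 (0.15 log units; within the scatter) and a 1.9-fold higher number from compound 2 to compound 3 (0.27 log units; within the scatter), stayed within it. The change from compound 3 to compound 4 keeps the methoxyphenyl pattern and adds one further substituent, so the expected step is small, a 1.2-fold lower number from compound 3 to compound 4 (0.09 log units; within the scatter), with no firm direction beyond the scatter.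

For compound 4 the estimate in this assay is 7500 nM, expected to fall between 3000 nM and 20000 nM.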

Compound 4, half-maximal inhibitory concentration: 17600 nM
Beside the measured number, compound 4's estimate is 2.3-fold (0.37 log units) below it, and the stated range covers the measured number.
By their numbers in this assay, from the lowest: compounds 2, 3, 1 and 4 (each within the scatter of the next, the first and the last beyond it).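

In this assay, going by these compounds alone, the one new step beyond the scatter is a 3.6-fold higher number from compound 2 to compound 4 (0.55 log units; beyond the scatter), which makes 2-fluoro-4-methoxyphenyl the second aryl group on the carbonyl carbon, after 4-chlorophenyl, to stand apart from 2-methylphenyl. The other two steps, a 1.9-fold higher number from compound 3 to compound 4 (0.28 log units; within the scatter) and a 1.4-fold higher number from compound 1 to compound 4 (0.14 log units; within the scatter), stay within the scatter, so the data do not separate 2-fluoro-4-methoxyphenyl from either 3-methoxyphenyl or 4-chlorophenyl. With four compounds, the position therefore shows only a shallow spread: compound 2 separates from compound 1 and compound 4 but not from compound 3, and compound 3 separates from none of the others, while the change from compound 3 to compound 4 alters the fluorine and the methoxy placement together, so this step cannot be assigned to either alteration.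

Nothing available accounts for any of these steps at this position. Still open, as far as these compounds go, is how far the number would move with a 4-methoxyphenyl or a 2-fluorophenyl on the carbonyl carbon, which would separate the two parts of this change, or with an aryl group carrying a carboxylic acid or an amine.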